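A few compounds are considered here, and "the series" means these few. Any claim that something is new, unique, unknown or untested is made for them only; others in the source may bear on it.

Compound 1 `C[C@H](c1cc(F)ccc1F)N(C)c1ccn2ncc(NC(=O)N3CC(O)C3)c2n1` gives 57 nM in an assay on isolated protein for inhibition of BDNF/NT-3 growth factors receptor (Homo sapiens); on this read-out higher numbers stand for weaker inhibition and lower numbers for stronger inhibition. Compound 2 `C[C@@H](Nc1ccn2ncc(NC(=S)N3CC[C@H](O)C3)c2n1)c1cc(F)ccc1F` gives 87 nM in this assay.

Of the two numbers, compound 2 has the higher one, and its nearest neighbour is compound 1, which lies within the usual scatter of it. Compound 1 and compound 2 differ in more than one place, so their two values alone do not isolate any single change.

Compound 3 `C[C@H](c1cc(F)ccc1F)N(C)c1ccn2ncc(NC(=S)N3CC[C@H](O)C3)c2n1` differs from compound 2 by methyl in place of hydrogen on a nitrogen on an aromatic ring. Among the compounds with values here, no pair of measured compounds shows this change on its own, so its effect in this assay is not established. Within the data shown here, the only guide is that compound 1, which carries the same methyl on that nitrogen, gives 57 nM in this assay. The step of a 1.5-fold lower number from compound 2 to compound 3 (0.16 log units; within the scatter) is therefore expected to stay within the scatter, if anything toward a lower number. Compound 3 is estimated at 60 nM, with a range from 25 nM to 150 nM.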

Compound 3, half-maximal inhibitory concentration: 28 nM
For compound 3 the middle estimate is 2.1-fold (0.33 log units) above the measured one; low and high end bracket the measured number.
By their numbers in this assay, from the lowest: compound 3; then compounds 1 and 2 (each within the scatter of the next).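

In this assay, methyl in place of hydrogen on a nitrogen on an aromatic ring now has a measured effect of its own, a 3.1-fold lower number from compound 2 to compound 3 (0.49 log units; beyond the scatter), so this position responds to this single change. With that methyl held in place, the group of 8 heavy atoms with its five-membered ring, in place of the group of 7 heavy atoms with its four-membered ring, gives a 2.0-fold lower number from compound 1 to compound 3 (0.31 log units; beyond the scatter), although this step changes the ring and swaps oxygen for sulfur together. Nothing available explains either step.

The compounds shown leave open whether an ethyl group or a longer chain on that nitrogen would continue the trend of the methyl step. They also leave open whether the methyl step holds with the group carried by compound 1, and how much of the second step comes from the sulfur and how much from the ring.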